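Swapping an amino chain for a hydroxypiperidine amide

A few compounds are considered here, and "the series" means these few. Any claim that something is new, unique, unknown or untested is made for them only; others in the source may bear on it.

Three compounds share one core. Compound 1 `CC(C)(C)c1ccc(C(=O)N2CCC3(CC2)C(=O)N(CC(=O)N2CCC(CCO)CC2)CN3c2ccccc2)cc1` gives 2600 nM in an assay on HEK293 cells for displacement of a labelled ligand from NPC1-like intracellular cholesterol transporter 1 (Homo sapiens); a lower number here means a stronger inhibitor, a higher number a weaker inhibitor; compound 2 `CC(C)(C)c1ccc(C(=O)N2CCC3(CC2)C(=O)N(CC(=O)NCN)CN3c2ccccc2)cc1` gives 26500 nM; compound 3 `CC(C)(C)c1ccc(C(=O)N2CCC3(CC2)C(=O)N(CC(=O)NCCCN)CN3c2ccccc2)cc1` gives 4200 nM, second highest of the three and nearest to compound 1. Compound 4 `CC(C)(C)c1ccc(C(=O)N2CCC3(CC2)C(=O)N(CC(=O)N2CCCC(O)C2)CN3c2ccccc2)cc1` carries 3-hydroxypiperidin-1-yl in place of (3-aminopropyl)amino on a carbonyl carbon. The step of a 1.6-fold higher number from compound 1 to compound 3 (0.21 log units; within the scatter) shows that a ring amide bearing a hydroxyl and an open amino chain give similar numbers, while a 10-fold higher number from compound 1 to compound 2 (1.01 log units; beyond the scatter) and a 6.3-fold lower number from compound 2 to compound 3 (0.80 log units; beyond the scatter) show that a short chain is much weaker. Compound 4 returns to a ring amide with a hydroxyl, so the expected step is a 1.7-fold lower number from compound 3 to compound 4 (0.23 log units; within the scatter), toward compound 1 and within the scatter. Compound 4 is therefore estimated at 2500 nM, between 1000 nM and 7000 nM.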

Compound 4, half-maximal inhibitory concentration: 12200 nM
For compound 4 the middle estimate is 4.9-fold (0.69 log units) below the measured one; the whole stated range lies below it.
By their numbers in this assay, from the lowest: compounds 1 and 3 (each within the scatter of the next); then compound 4; then compound 2.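

On this carbonyl carbon, a ring amide with a hydroxyl does not by itself hold the number down: 3-hydroxypiperidin-1-yl gives a 2.9-fold higher number from compound 3 to compound 4 (0.46 log units; beyond the scatter) and, against the other ring amide, a 4.7-fold higher number from compound 1 to compound 4 (0.67 log units; beyond the scatter) so the ring's substituent matters. It still beats the shortest chain, with a 2.2-fold lower number from compound 2 to compound 4 (0.34 log units; beyond the scatter) as the step. No measured evidence here explains these steps.

Still open, from the compounds shown here alone, is how a plain piperidin-1-yl amide without a hydroxyl would compare. Going by these compounds, a morpholine amide or an aminobutyl chain on the same carbonyl carbon also remains untested by these compounds.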